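The source may hold more compounds than are shown below. What is called first, only, known or untested is meant among the compounds shown, and "the series" means these compounds.

Measured in a functional assay on SF-268 cells (Homo sapiens) for cytotoxicity; a lower number here means a stronger inhibitor, a higher number a weaker inhibitor:

Compound 1 `Oc1cc2cc(c1)Oc1c(O)cc(cc1O)[C@H](O)CCCCCC/C=C/CCCCC2` gives 31300 nM.
Compound 2 `Oc1cc2cc(c1)Oc1c(O)cc(cc1O)CCCCCCC/C=C/CCCCC2` gives 33100 nM.
Compound 3 `Oc1cc2cc(c1)Oc1c(O)cc(cc1O)[C@H](O)CCCCCCCCCCCCC2` gives 32100 nM.

All three numbers sit within the scatter of one another, so no order among compounds 1, 2 and 3 is claimed here. For the measured compounds named here, the one counted change among the measured compounds is hydrogen in place of hydroxy on a saturated ring carbon, and it gave a 1.1-fold higher number from compound 1 to compound 2 (0.02 log units; within the scatter). The difference between the core of compound 3 and the core of compound 1 is not broken down here; their two values are, in any case, indistinguishable in this assay.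

Compound 4 `Oc1cc2cc(c1)Oc1c(O)cc(cc1O)CCCCCCCCCCCCCC2` has not yet been measured. It relates to compound 3 as compound 2 relates to compound 1: the change is hydrogen in place of hydroxy on a saturated ring carbon, and the two places are described in the same words, so it is taken as the same change. Since the earlier step was flat, the step from compound 3 to compound 4 is expected to be a 1.1-fold higher number from compound 3 to compound 4 (0.02 log units; within the scatter), resting on the step from compound 1 to compound 2 being within the scatter. Compound 4 is therefore estimated at 34000 nM, with an expected range from 20000 nM to 60000 nM.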

Compound 4, half-maximal inhibitory concentration: 32700 nM
Estimate against measurement, compound 4: 1.0-fold (0.02 log units) above, and the stated range covers the measured number.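

In this assay, hydrogen in place of hydroxy on a saturated ring carbon gives a 1.0-fold higher number from compound 3 to compound 4 (0.01 log units; within the scatter), so the change is as flat on the core of compound 3 as it was on the core of compound 1. Set side by side, the two steps show no detectable difference between the cores: the same change on two cores in this assay, a 1.1-fold higher number (0.02 log units; within the scatter) from compound 1 to compound 2 and a 1.0-fold higher number (0.01 log units; within the scatter) from compound 3 to compound 4, 1.0-fold (0.02 log units) apart, within the scatter of two such steps. This shows that the change can be carried between these two cores in this one assay without a measurable shift in the read-out, but it does not show that the same would hold on any other core or in any other assay.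

The compounds shown leave open whether a different group on that saturated ring carbon, such as an amine, a methoxy group or a carboxylic acid, would separate from hydroxy and hydrogen in this read-out. They also leave open what the opposite configuration at the hydroxy-bearing carbon, or a shorter or longer chain in the large ring, would give.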